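Swapping 2-Methylcyclohexyl for 4-Fluorophenyl on the Carbonyl

This account rests on a few compounds, and the source may have more. Where it says the series, first, only, none or still open, it means among the compounds named here.

Compound 1 `CC1CCCCC1C(=O)N1CC(c2nc(-c3cccc(F)c3)no2)C1` was tested in an assay on HEK293 cells for positive allosteric modulation of metabotropic glutamate receptor 5 (Homo sapiens), read by FLIPR (on this read-out higher numbers stand for an effect only at larger amounts of compound and lower numbers for an effect already at smaller amounts), where compound 1 gives 540 nM. Going by the values given here, that is the only numerical value in the set, so compound 1 stands alone as the reference point. Among the compounds with values here, compound 2 `Cc1ccc(S(=O)(=O)N2CC(c3nc(-c4cccc(C)c4)no3)C2)cc1` differs from it in more than one place, so no single step connects the two. In this assay compound 2 gives > 10000 nM, which is a limit of the assay and not a number: compound 2 sits at the limit of > 10000 nM in this assay, at which 1 of the 2 values shown sits. Within the data shown here, the two values show only that compound 1 gives a number while compound 2 does not.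

Compound 3 `O=C(c1ccc(F)cc1)N1CC(c2nc(-c3cccc(F)c3)no2)C1` is the untested member. It differs from compound 1 by 4-fluorophenyl in place of 2-methylcyclohexyl on a carbonyl carbon, in words 4-fluorophenyl in place of 2-methylcyclohexyl on a carbonyl carbon. Among the measured compounds shown here, no measured pair shows what such a change does in this assay, so the expectation rests on compound 1 alone. The step of a 1.1-fold lower number from compound 1 to compound 3 (0.03 log units; within the scatter) is expected to be modest, most likely within the usual scatter and without a clear direction, though a larger shift either way cannot be excluded. Compound 3 is therefore estimated at 500 nM, with a range from 120 nM to 2500 nM.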

Compound 3, half-maximal effective concentration: 2400 nM
Beside the measured number, compound 3's estimate is 4.8-fold (0.68 log units) below it; the measured number falls inside the stated range.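

The carbonyl carbon now has its first readable step: in this assay, 4-fluorophenyl in place of 2-methylcyclohexyl on a carbonyl carbon gives a 4.4-fold higher number from compound 1 to compound 3 (0.65 log units; beyond the scatter). The two groups have the same count of heavy atoms, and neither carries a hydrogen-bond donor, a hydrogen-bond acceptor or a net charge, yet they differ in that one ring is aromatic, the other is not, and only one carries fluorine, so this position does not treat a swap of equal size as neutral in this one pair. Nothing given here accounts for the size or direction of this step.

What the compounds shown leave open is which part of the swap matters, as the aromatic ring and the fluorine enter together, and an unsubstituted phenyl or an unsubstituted cyclohexyl on the same carbonyl would be needed to separate them. Also open, on these data alone, is how this position responds to groups of another kind, such as a straight butyl chain, a methoxy-bearing phenyl or a ring holding an amine, since a single step cannot establish a trend.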